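The source may hold more compounds than are shown below. What is called first, only, known or untested is meant among the compounds shown, and "the series" means these compounds.

In a functional assay on PC-3 cells (Homo sapiens) (a lower number here means a stronger inhibitor of growth, a higher number a weaker inhibitor of growth), compound 1 (`O=S(=O)(/C=C/c1ccccc1)Cc1ccc(Nc2ncnc3ccccc23)cc1`), which carries a plain phenyl on the ethenyl chain, reaches only a limit of the assay, > 100000 nM. Compound 2 (`O=S(=O)(/C=C/c1ccc(Cl)c(Cl)c1)Cc1ccc(Nc2ncnc3ccccc23)cc1`) gives 35000 nM. Compound 3 (`O=S(=O)(/C=C/c1ccc(Br)cc1)Cc1ccc(Nc2ncnc3ccccc23)cc1`) gives 42000 nM, so it stands level with compound 2 within the scatter.

Next in line is compound 4 (`O=S(=O)(/C=C/c1ccc(Cl)cc1)Cc1ccc(Nc2ncnc3ccccc23)cc1`), not yet measured in this assay. The change is chloro in place of bromo on an aromatic carbon, para to a large group: chloro in place of bromo on an aromatic carbon.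

Among the measured compounds shown here, three measured steps bear on it. Placing halogen on the phenyl gave an at least 2.3-fold lower number from compound 1 to compound 3 (0.37 log units; beyond the scatter) and an at least 2.8-fold lower number from compound 1 to compound 2 (0.45 log units; beyond the scatter). Both are bounded on one side only, as they start from a limit. The step that compares the two halogenated rings directly is a 1.2-fold higher number from compound 2 to compound 3 (0.08 log units; within the scatter), so the 3,4-dichlorophenyl of compound 2 and the 4-bromophenyl of compound 3 do not separate. For the measured compounds named here, no measured pair exchanges bromo for chloro at a single place. On this basis, the step expected is a 1.1-fold lower number from compound 3 to compound 4 (0.02 log units; within the scatter), with no change beyond the scatter. Compound 4 is expected at 40000 nM, with an estimated range of 22000 nM to 75000 nM.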

Compound 4, concentration for 50% growth inhibition: 43000 nM
The estimate for compound 4 lay 1.1-fold (0.03 log units) below the measured number; the range from low to high includes it.
By their numbers in this assay, from the lowest: compounds 2, 3 and 4 (each within the scatter of the next). At a limit, above all of these: compound 1.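

In this assay, among the compounds shown here, the first direct exchange of one halogen for another at this place, on an aromatic carbon para to a large group, gives a 1.0-fold higher number from compound 3 to compound 4 (0.01 log units; within the scatter), so chloro and bromo do not separate here. The second ring chlorine also proves dispensable within this set, with a 1.2-fold higher number from compound 2 to compound 4 (0.09 log units; within the scatter), which places the 4-chlorophenyl, 4-bromophenyl and 3,4-dichlorophenyl compounds level within the scatter. A single chloro is thus already enough to give a measurable number, with an at least 2.3-fold lower number from compound 1 to compound 4 (0.36 log units; beyond the scatter), a step bounded on one side only because its starting point, compound 1, is a limit of the assay: the limit of > 100000 nM in this assay, at which 1 of the 4 values shown sits.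

The compounds shown leave open whether the gain belongs to halogens as such or to any substituent at this place, which a methoxy, an amine or a carboxylic acid on the same ring carbon would test. They also leave open whether any change on this ring can move the number beyond the level shared by compound 2, compound 3 and compound 4, and how large the true step from the plain phenyl of compound 1 is.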